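The compounds below may be only part of what the source reports. "The series", "measured", "known", "first", "only" and "open" are said of these compounds alone.

Measured values in an ADME assay on MT4 cells (Homo sapiens) for cytotoxicity, read by MTT assay, with a stated time of 96 h; a lower number here means that less compound is tolerated, a higher number that more compound is tolerated:
Compound 1 `CCC(=O)Nc1ccc(-c2nc3cc(C(F)(F)F)ccc3n2C2CCCCC2)cc1` gives 17000 nM.
Compound 2 `CCC(=O)Nc1ccc(-c2nc3cc(C(F)(F)F)ccc3[nH]2)cc1` reaches only the assay limit, >= 100000 nM.
Compound 3 `CCC(=O)Nc1ccc(-c2nc3ccccc3[nH]2)cc1` gives 35000 nM.

Compound 2 therefore stands at the upper boundary of the numbers shown, with a limit and no number (the limit of >= 100000 nM in this assay, at which 1 of the 3 values shown sits). The step from compound 2 to compound 4 `Fc1ccc(-c2nc3cc(C(F)(F)F)ccc3[nH]2)cc1` is fluoro in place of propanoylamino on an aromatic carbon. Within the data shown here, neither measured step touches that group: an at least 5.8-fold higher number from compound 1 to compound 2 (0.76 log units; beyond the scatter) and an at least 2.8-fold lower number from compound 2 to compound 3 (0.45 log units; beyond the scatter) both alter the shared core and leave the propanoylamino side untouched, so no measured pair supports the change to fluoro. With compound 2 already at the limit, no step beyond the scatter is expected in this assay, and compound 4 is estimated at 100000 nM (range 40000 nM to 250000 nM), a step of a number no higher from compound 2 to compound 4 (the limit leaves the size open) expected to sit within the scatter, most likely again reported only as a limit.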

Compound 4, half-maximal cytotoxic concentration: 22000 nM
Compound 4: the middle estimate sits 4.5-fold (0.66 log units) above what was measured; measured number below the stated range.
By their numbers in this assay, from the lowest: compounds 1, 4 and 3 (each within the scatter of the next, the first and the last beyond it). At a limit, above all of these: compound 2.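

Among these compounds, replacing propanoylamino with fluoro gives an at least 4.5-fold lower number from compound 2 to compound 4 (0.65 log units; beyond the scatter) in this assay, the only measured change at this position, para to a large group. With the shared core held constant, the read-out therefore responds to this position as well as to the core changes. Compound 2 stands at a limit, so the step gives only a minimum size: the limit of >= 100000 nM in this assay, at which 1 of the 4 values shown sits.

Whether the lower number follows the departure of propanoylamino or the arrival of fluoro stays open: only these two groups are shown at this position. An amine, a carboxylic acid or a longer acyl chain there would help separate the two.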